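The source may report more compounds than this note shows. Statements on the series, on what has been measured and on what is new or still open speak of the compounds shown alone.

Measured so far:
- compound 1 `Cc1cc2c(cc1C(=O)N=C(N)N)S(=O)(=O)C(C)(C)C2(C)O`: in an assay on cells for inhibition of sodium/hydrogen exchanger (Oryctolagus cuniculus) (on this read-out lower numbers stand for stronger inhibition and higher numbers for weaker inhibition), compound 1 gives 17 nM
- compound 2 `Cc1cc2c(cc1C(=O)N=C(N)N)S(=O)(=O)C(C)(C)C2C`: in this assay compound 2 gives 14 nM

Compound 2 has the lowest of the two numbers, but its step from compound 1 is a 1.2-fold lower number from compound 1 to compound 2 (0.08 log units; within the scatter), so the two compounds cannot be told apart by this read-out. The only variation seen so far sits on the saturated ring carbon of the shared core, where compound 1 carries a hydroxy beside the methyl and compound 2 carries only the methyl.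

Compound 3 `Cc1cc2c(cc1C(=O)N=C(N)N)S(=O)(=O)C(C)(C)C2O` changes the same carbon once more: hydroxy in place of methyl on a saturated ring carbon. Going by the values given here, the one measured step that bears on this position, from compound 1 to compound 2, removed a hydroxy and stayed within the scatter. Taking a methyl away while keeping a hydroxy has not been tested, so the comparison is indirect; still, the indifference of this assay to the hydroxy in that step suggests no large effect. Compound 3 is therefore expected to come out close to compound 2, with a step of a 1.4-fold higher number from compound 2 to compound 3 (0.15 log units; within the scatter) at most a little weaker. The estimate for compound 3 in this assay is 20 nM, in a range from 8 nM to 50 nM.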

Compound 3, half-maximal inhibitory concentration: 28 nM
The estimate for compound 3 lay 1.4-fold (0.15 log units) below the measured number; the range from low to high includes it.
By their numbers in this assay, from the lowest: compounds 2, 1 and 3 (each within the scatter of the next).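

Replacing the methyl with a hydroxy gives a 2.0-fold higher number from compound 2 to compound 3 (0.30 log units; within the scatter) in this assay and is the largest step among the three compounds, yet it still does not separate them. The step of a 1.6-fold higher number from compound 1 to compound 3 (0.22 log units; within the scatter) supplies what the first pair could not, a direct test of taking the methyl away while the hydroxy stays, and it too remains unresolved by this read-out. This saturated ring carbon has now carried a methyl, a hydroxy and both together, and none of these three forms can be told apart from the others, although no data here explain this.

On these data alone, what remains open is whether this carbon is equally undemanding toward groups of another kind, such as an amine, a carboxylic acid or a longer chain like propyl, any of which might move the number well beyond the scatter. As far as these compounds go, it is also open whether a carbon bearing only hydrogens, with neither methyl nor hydroxy, would read like these three compounds, and so whether any substituent at this position matters at all.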